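A few compounds are considered here, and "the series" means these few. Any claim that something is new, unique, unknown or untested is made for them only; others in the source may bear on it.

In a physicochemical assay for lipophilicity (a higher number here means a more lipophilic compound, a lower number a more polar compound), compound 1 `CNCC(=O)Nc1ccc(-c2nc(C(C)(C)S(C)(=O)=O)cc([C@]34CCOC[C@H]3C4)n2)cc1` gives 4.3. Among the compounds with values here, its mirror image, compound 2 `CNCC(=O)Nc1ccc(-c2nc(C(C)(C)S(C)(=O)=O)cc([C@@]34CCOC[C@@H]3C4)n2)cc1`, gives 4.3, so these two stand level as the highest of the three numbers so far. Compound 3 `CNCC(=O)Nc1ccc(-c2nc(CS(C)(=O)=O)cc([C@]34CCOC[C@H]3C4)n2)cc1` gives 3.1.

Compound 4 `CC(C)(c1cc([C@]23CCOC[C@H]2C3)nc(-c2ccc(NC(=S)NCCO)cc2)n1)S(C)(=O)=O` keeps the core of compound 1 and differs in one place, on a nitrogen on an aromatic ring: a group of 6 heavy atoms (3 carbon, 1 nitrogen, 1 oxygen, 1 sulfur; no ring) in place of a group of 5 heavy atoms (3 carbon, 1 nitrogen, 1 oxygen; no ring), on a nitrogen on an aromatic ring. Neither measured step touches that place. The step of no change at the digits printed from compound 1 to compound 2 (within the scatter) stays within the scatter, due to the fact that compounds 1 and 2 differ only in the configuration as drawn. The step of a number 1.20 log units lower from compound 1 to compound 3 (beyond the scatter) is large, but it replaces the 1-methyl-1-(methylsulfonyl)ethyl on an aromatic carbon, elsewhere in the molecule. Within the data shown here, it shows only that a single exchange can move these numbers far, and no measured step guides this exchange directly.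

A moderate fall in this assay is therefore expected, smaller than that large step, though a small rise cannot be excluded. The estimated change is a number 0.60 log units lower from compound 1 to compound 4 (beyond the scatter). For compound 4 the expected value is 3.7, within a range from 3 to 4.4.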

Compound 4, partition coefficient: 3.9
Compound 4: middle estimate off by 0.20 log units, on the low side, within the range that was stated.
By their numbers in this assay, from the lowest: compound 3; then compound 4; then compounds 1 and 2 (each within the scatter of the next).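

In this assay, the exchange on a nitrogen on an aromatic ring gives a number 0.40 log units lower from compound 1 to compound 4 (beyond the scatter), the first measured sign that a change at this place can move the number beyond the scatter. Neither the group that leaves nor the group that enters has a ring or a net charge, so this step comes from an exchange between two open-chain, uncharged groups, at a different place from the large step to compound 3. Nothing in the information at hand explains why the number falls with this exchange.

A single exchange at this nitrogen leaves open how a carboxylic acid, a ring-bearing amine or a longer chain would behave there. It also leaves open whether the same exchange would give a similar step on compound 2 or compound 3.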